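The source may report more compounds than this note shows. Statements on the series, on what has been measured and on what is new or still open speak of the compounds shown alone.

Three compounds of the series carry numbers in an assay on cell membranes for binding affinity to 2-oxoglutarate receptor 1 (Rattus norvegicus), read by radioligand binding; on this read-out lower numbers stand for stronger inhibition and higher numbers for weaker inhibition. Compound 1 `CCC(C)NC(=O)[C@H]1OC(n2cnc3c(N)ncnc32)[C@H](O)[C@@H]1O` gives 198 nM. Compound 2 `NCCCCCCCCNC(=O)[C@H]1OC(n2cnc3c(N)ncnc32)[C@H](O)[C@@H]1O` gives 29 nM, and compound 3 `CC(=O)NCCNC(=O)[C@H]1OC(n2cnc3c(N)ncnc32)[C@H](O)[C@@H]1O` gives 46 nM. Compound 3 thus stands second highest of the three: a 1.6-fold higher number from compound 2 to compound 3 (0.20 log units; within the scatter) lies within the scatter, while a 4.3-fold lower number from compound 1 to compound 3 (0.63 log units; beyond the scatter) lies beyond it, as does a 6.8-fold lower number from compound 1 to compound 2 (0.83 log units; beyond the scatter). Compound 4 `Nc1ncnc2c1ncn2C1O[C@H](C(=O)NC2CCCCCCC2)[C@@H](O)[C@H]1O` carries cyclooctyl in place of 2-acetamidoethyl on an amide-type nitrogen. Within the data shown here, no measured step puts a ring on this nitrogen; the step that bears most on it is a 4.3-fold lower number from compound 1 to compound 3 (0.63 log units; beyond the scatter), which went from the sec-butyl of compound 1 to the 2-acetamidoethyl of compound 3. Going back to a plain carbon group, a modest rise in this assay is expected, a 2.6-fold higher number from compound 3 to compound 4 (0.42 log units; beyond the scatter). For compound 4 the estimate is 120 nM, with a range of 30 nM to 500 nM.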

Compound 4, inhibition constant: 23 nM
Compound 4: the middle estimate sits 5.2-fold (0.72 log units) above what was measured; the whole stated range lies above it.
By their numbers in this assay, from the lowest: compounds 4, 2 and 3 (each within the scatter of the next); then compound 1.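

On the amide-type nitrogen in this assay, cyclooctyl gives an 8.6-fold lower number from compound 1 to compound 4 (0.93 log units; beyond the scatter), a step beyond the scatter that shows an all-carbon group can match the substituents of compound 2 and compound 3, even though the all-carbon sec-butyl of compound 1 stands apart. Both a 2.0-fold lower number from compound 3 to compound 4 (0.30 log units; within the scatter) and a 1.3-fold lower number from compound 2 to compound 4 (0.10 log units; within the scatter) stay within the scatter, so a substituent with no hydrogen-bond donors or acceptors sits level with these two chains. No supporting data explain this result.

As far as these compounds go, whether the ring or the carbon count separates compound 4 from compound 1 remains open. An unbranched octyl chain and a cyclopentyl group on this nitrogen would bear on that question.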